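A few compounds are considered here, and "the series" means these few. Any claim that something is new, unique, unknown or untested is made for them only; others in the source may bear on it.

Working notes on the series. Two compounds have numbers in an assay on HEK293 cells for displacement of a labelled ligand from Neuronal acetylcholine receptor; alpha4/beta2 (Homo sapiens); on this read-out lower numbers stand for stronger inhibition and higher numbers for weaker inhibition. Compound 1 `C=COc1cc(N2CCCNCCC2)cnc1Br` gives 0.38 nM in this assay and stands lowest of the two numbers. Compound 2 `c1ccc2ncc(N3CCCNCC3)cc2c1` gives 6.61 nM in this assay, a number higher than that of compound 1 by a margin beyond the scatter. Among the measured compounds shown here, no step between measured compounds that differ in one place is available, so the two values show only that compound 1 is the stronger inhibitor of the pair and compound 2 the weaker.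

Compound 3 `Brc1ccc(N2CCCNCCC2)cn1` has not yet been measured in this assay. It differs from compound 1 as follows: hydrogen in place of vinyloxy on an aromatic carbon. The measured pair shows nothing about what the vinyloxy group contributes, since compound 2 differs from compound 1 in more than one place. With the vinyloxy group removed from the core of compound 1, the step is expected to run upward, toward weaker inhibition, by a moderate margin beyond the scatter. The estimated step is a 3.9-fold higher number from compound 1 to compound 3 (0.60 log units; beyond the scatter). Compound 3 is thus expected to give 1.5 nM in this assay, within a range of 0.4 nM to 6 nM.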

Compound 3, half-maximal inhibitory concentration: 0.447 nM
The estimate for compound 3 lay 3.4-fold (0.53 log units) above the measured number; the measured number falls inside the stated range.
By their numbers in this assay, from the lowest: compounds 1 and 3 (each within the scatter of the next); then compound 2.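

Among the compounds shown here, the change of hydrogen in place of vinyloxy gives a 1.2-fold higher number from compound 1 to compound 3 (0.07 log units; within the scatter) in this assay, the first direct reading at this position, on an aromatic carbon ortho to a bromo group. In this assay, the low number of compound 1 therefore does not rest on the vinyloxy group: the loss of its 3 heavy atoms, its double bond outside aromatic rings and its hydrogen-bond acceptor leaves compound 3 within the scatter of compound 1. No supporting measurement bears on this result.

As far as these compounds go, whether the position accepts any group in the same way remains open, since only hydrogen and vinyloxy are compared here, and an amine, a carboxylic acid or a longer chain such as butoxy could give a different number. Also open, from the compounds shown here alone, is whether the same holds without the bromo group or on another core, such as that of compound 2, which differs from compound 1 in more than one place.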